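The source may report more compounds than this note shows. Statements on the series, on what has been measured and on what is new or still open speak of the compounds shown alone.

Three related compounds have been tested so far in a functional assay on IMR-32 cells (Homo sapiens) for antiproliferative activity, with a stated time of 72 h; a higher number here means a weaker inhibitor, a lower number a stronger inhibitor. Compound 1 `Cc1ccc(CNC(=O)CCN(Cc2ccc(C(=O)NO)cc2)C(=O)c2ccc(N(C)C)cc2)cc1` gives 260 nM, the lowest number of the three and so the strongest inhibitor among them. Compound 3 `Cc1ccc(NC(=O)CCN(Cc2ccc(C(=O)NO)cc2)C(=O)c2ccccc2)cc1` gives 550 nM, and compound 2 `COc1cc(OC)cc(C(=O)N(CCC(=O)NCc2ccccc2)Cc2ccc(C(=O)NO)cc2)c1` gives 6040 nM.

The compound still to be measured, compound 4 `CN(C)c1ccc(C(=O)N(CCC(=O)NCc2ccc(Cl)cc2)Cc2ccc(C(=O)NO)cc2)cc1`, keeps the core of compound 1 and changes it in one place: the 4-methylbenzyl group becomes a 4-chlorobenzyl group, (chloro in place of methyl on an aromatic carbon). Put simply, this is chloro in place of methyl on an aromatic carbon, para to a large group.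

The three measured compounds differ from one another in more than one place, so none of their comparisons shows what this swap does on its own. The only firm starting point is compound 1 at 260 nM. Compound 2 at 6040 nM shows that numbers in this small set can lie far apart, but it differs from compound 1 by more than a single swap of this kind. With no direct evidence, no step beyond the scatter is expected, and neither direction is favoured. The estimated step, a 1.0-fold lower number from compound 1 to compound 4 (0.02 log units; within the scatter), is therefore small. For compound 4 the estimated value is 250 nM, with an expected range from 110 nM to 600 nM.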

Compound 4, half-maximal inhibitory concentration: 310 nM
The estimate for compound 4 lay 1.2-fold (0.09 log units) below the measured number; the range from low to high includes it.
By their numbers in this assay, from the lowest: compounds 1, 4 and 3 (each within the scatter of the next, the first and the last beyond it); then compound 2.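

Within the data shown here, compound 1 and compound 4 form the first pair in this set that differ in one place only, so the swap from 4-methylbenzyl to 4-chlorobenzyl can now be read on its own. In this assay this swap gives a 1.2-fold higher number from compound 1 to compound 4 (0.08 log units; within the scatter) and so produces no real difference in antiproliferative activity. Among these compounds, with the rest of the core of compound 1 held constant, methyl and chloro on this aromatic carbon cannot be told apart in this assay, which the earlier compounds could not show. No measurement here explains why the two groups give such similar results.

This single pair says nothing about how a methoxy group, an amine or a carboxylic acid on the same aromatic carbon would behave, so it does not show that this position accepts substituents in general. It also leaves open whether chloro in place of methyl would give a similarly small step on a compound with a different amide part, such as compound 3, where the methyl-bearing ring is attached directly to the amide nitrogen.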